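Amide aryl variation in a fluorophenyl chromenone series

The compounds below may be only part of what the source reports. "The series", "measured", "known", "first", "only" and "open" are said of these compounds alone.

Measured compounds:
compound 1 `O=C(Nc1cccc(-c2oc3cc(-c4ccc(F)cc4)ccc3c(=O)c2O)c1)c1ccc(Cl)cc1`: 4030 nM
compound 2 `O=C(Nc1cccc(-c2oc3cc(-c4ccc(F)cc4)ccc3c(=O)c2O)c1)c1ccc(C(F)(F)F)cc1`: 7350 nM
compound 3 `COc1cccc(C(=O)Nc2cccc(-c3oc4cc(-c5ccc(F)cc5)ccc4c(=O)c3O)c2)c1`: 18900 nM

All three share one core and differ only in the aryl group on the amide carbonyl carbon. Readings come from a functional assay on HCC1937 cells (Homo sapiens) for antiproliferative activity, read by CCK-8 assay, with a stated time of 72 h; on this read-out lower numbers stand for stronger inhibition and higher numbers for weaker inhibition. Compound 3 gives the highest number of the three; the nearest is compound 2, and the furthest is compound 1, with a 2.6-fold higher number from compound 2 to compound 3 (0.41 log units; beyond the scatter) and a 4.7-fold higher number from compound 1 to compound 3 (0.67 log units; beyond the scatter). Between compound 1 and compound 2 the change is a 1.8-fold higher number from compound 1 to compound 2 (0.26 log units; within the scatter).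

Compound 4 `O=C(Nc1cccc(-c2oc3cc(-c4ccc(F)cc4)ccc3c(=O)c2O)c1)c1ccc(Cl)nc1` carries the change (6-chloropyridin-3-yl in place of 3-methoxyphenyl on a carbonyl carbon). Among the measured compounds shown here, two measured steps bear on it, both ending at compound 3 and both beyond the scatter: a chloro-bearing aryl on the carbonyl gives the lowest number of the set, and the 3-methoxyphenyl compound 3 sits highest. Compound 4 brings a chloro back onto the carbonyl aryl, though on a pyridine rather than a phenyl ring, so a move back toward the region of compound 1 and compound 2 is expected, of size a 3.4-fold lower number from compound 3 to compound 4 (0.54 log units; beyond the scatter). For the measured compounds named here, the pyridine nitrogen has no precedent in this set, so the expectation is held loosely. Compound 4 is estimated at 5500 nM, with a range of 2200 nM to 14000 nM.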

Compound 4, half-maximal inhibitory concentration: 7550 nM
Estimate against measurement, compound 4: 1.4-fold (0.14 log units) below; the measured number falls inside the stated range.
By their numbers in this assay, from the lowest: compounds 1, 2 and 4 (each within the scatter of the next); then compound 3.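

In this assay, the move away from 3-methoxyphenyl on the carbonyl carbon still holds when the incoming aryl ring carries a nitrogen (a step of a 2.5-fold lower number from compound 3 to compound 4 (0.40 log units; beyond the scatter)), so a chloro-bearing ring at this position need not be a phenyl ring. The 6-chloropyridin-3-yl group cannot be separated from either of the other two groups (steps of a 1.0-fold higher number from compound 2 to compound 4 (0.01 log units; within the scatter) and a 1.9-fold higher number from compound 1 to compound 4 (0.27 log units; within the scatter)), which means the ring nitrogen makes no readable difference against 4-chlorophenyl and that compound 3 alone stands apart from the other three compounds. Nothing on hand accounts for the position of compound 3 or for the flat readings of the other three.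

A 4-methoxyphenyl or a 3-chlorophenyl group on the same carbonyl carbon would show whether the standing of compound 3 follows the methoxy group or its place on the ring. Going by these compounds, it also stays open whether an aminopyridine or a benzoic acid ring at this position, or a longer alkyl chain in place of the aryl ring, would separate from compound 1, compound 2 and compound 4.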